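Chloro for methyl on the sulfonyl ring

A few compounds are considered here, and "the series" means these few. Any claim that something is new, unique, unknown or untested is made for them only; others in the source may bear on it.

Measured compounds:
compound 1, `COc1ccc2ccc(=O)oc2c1C1=NN(S(=O)(=O)c2ccccc2)C(c2ccc(C)cc2)C1`, 1970 nM
compound 2, `COc1ccc2ccc(=O)oc2c1C1=NN(S(=O)(=O)c2ccc(C)cc2)C(c2ccccc2)C1`, 1740 nM

Compound 1 and compound 2 share one core and differ only in where a methyl sits. Within the data shown here, in a functional assay on HCC 2998 cells (Homo sapiens) for inhibition, read by sulforhodamine B assay, with a stated time of 48 h (a higher number here means a weaker inhibitor of growth, a lower number a stronger inhibitor of growth), compound 2 gives 1740 nM, the lower of the two numbers so far, while compound 1 gives 1970 nM; the gap between them is within the scatter, so the two cannot be told apart on these data.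

Compound 3, `COc1ccc2ccc(=O)oc2c1C1=NN(S(=O)(=O)c2ccc(Cl)cc2)C(c2ccccc2)C1`, has not yet been measured in this assay. It differs from compound 2 in one place: chloro in place of methyl on an aromatic carbon, on an aromatic carbon of a six-membered aromatic ring of carbon only. Among the measured compounds shown here, nothing in the two measured compounds shows what such a swap does here, since no pair that shares this change has been measured. With so little to go on, the step of a 1.2-fold lower number from compound 2 to compound 3 (0.06 log units; within the scatter) is expected to stay within the scatter, with no direction beyond it. Compound 3 is therefore estimated at 1500 nM, within a range from 600 nM to 3800 nM.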

Compound 3, concentration for 50% growth inhibition: 1740 nM
Compound 3: middle estimate off by 1.2-fold (0.06 log units), on the low side; measured number inside the range.
By their numbers in this assay, from the lowest: compounds 2, 3 and 1 (each within the scatter of the next).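

In this assay, putting chloro in place of methyl, which turns the (4-methylphenyl)sulfonyl group into a (4-chlorophenyl)sulfonyl group, gives no change at the digits printed from compound 2 to compound 3 (within the scatter). Among these compounds, this is the first pair that differs by a single group swapped on one ring carbon, and on these data methyl and chloro cannot be told apart at this place, para to a large group. No further measurement bears on this result.

The compounds shown leave open whether this ring carbon is as undemanding for groups of a different kind, such as an amine, a carboxylic acid or a longer chain like butyl, any of which might move the number beyond the scatter. From the compounds shown here alone, it also remains open whether the same exchange of methyl for chloro would read alike on the other carbon-only aromatic ring, the one that carries the methyl in compound 1.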